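This account rests on a few compounds, and the source may have more. Where it says the series, first, only, none or still open, it means among the compounds named here.

Series notes. The shared core of compound 1 `Oc1ccccc1-c1cc(-c2cccc(C(F)(F)F)c2)cc(-c2ccccc2O)n1` carries two 2-hydroxyphenyl groups and a third aryl group. Compound 2 `Oc1ccccc1-c1cc(-c2ccc(C(F)(F)F)cc2)cc(-c2ccccc2O)n1` is built from the same atoms joined differently: 4-(trifluoromethyl)phenyl in place of 3-(trifluoromethyl)phenyl on an aromatic carbon. Compound 3 `Oc1ccccc1-c1cc(-c2cccc(OC(F)(F)F)c2)cc(-c2ccccc2O)n1` and the not yet measured compound 4 `Oc1ccccc1-c1cc(-c2ccc(OC(F)(F)F)cc2)cc(-c2ccccc2O)n1` follow from these by one further exchange each.

Measured in a functional assay on HeLa cells (Homo sapiens) for inhibition (on this read-out higher numbers stand for weaker inhibition and lower numbers for stronger inhibition), compound 1 returns only a limit of the assay, > 50000 nM. In this assay compound 2 likewise returns only a limit, > 50000 nM. Compound 3 in this assay also returns a limit, > 50000 nM.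

Accordingly a step that the two limits leave unreadable from compound 1 to compound 2, and a step that the two limits leave unreadable from compound 1 to compound 3; all three values sit at the limit of > 50000 nM in this assay, at which 3 of the 3 values shown sit, so neither step has a readable size.

The change from compound 1 to compound 3 is trifluoromethoxy in place of trifluoromethyl on an aromatic carbon. The same kind of change, not the same, takes compound 2 to compound 4: trifluoromethoxy in place of trifluoromethyl on an aromatic carbon. Around the place the two differ only in that the group sits meta to a large group in the first pair and para to a large group in the second.

Expected: a step that the limit leaves unreadable from compound 2 to compound 4, a step that rests on (the limit of > 50000 nM in this assay, at which 3 of the 3 values shown sit), since nothing among the three measured compounds has yet risen off it. Compound 4 is therefore expected in this assay at 60000 nM, estimated between 20000 nM and 200000 nM, most probably reported again as a limit of the assay.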

Compound 4, half-maximal inhibitory concentration: > 50000 nM
Compound 4 gave a limit, no number (the forecaster's own chance of this, stated with the estimate: 85%); the middle value lies beyond the limit too.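

Among these compounds, compound 4, like compound 2, returns only a limit in this assay, so trifluoromethoxy in place of trifluoromethyl gives no step of readable size between them. All values in the series rest on the same limit: the limit of > 50000 nM in this assay, at which 4 of the 4 values shown sit. The compounds shown leave open whether any exchange on the third aryl group of the shared core yields a measurable inhibition in this assay.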